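The compounds below may be only part of what the source reports. "The series", "measured", "known", "first", "only" and "open" are said of these compounds alone.

Of the compounds shown here, two from one series have been measured in an ADME assay on microsomes from liver (Rattus norvegicus) for metabolic stability; a lower number here means that the compound disappears faster, a higher number that the compound lasts longer. Compound 1 `CC#C[C@@H](Cc1nnn[nH]1)c1ccc(OCc2ccc3scc(-c4cc(OCCOC)ccc4C)c3c2)cc1` gives 0.367 h in this assay. Compound 2 `CC#C[C@@H](Cc1nnn[nH]1)c1ccc(OCc2ccc3scc(-c4cccnc4C)c3c2)cc1` gives 0.183 h in this assay. Among the measured compounds shown here, compound 2 has the lowest of the two numbers, and its only neighbour is compound 1; the step of a 2.0-fold lower number from compound 1 to compound 2 (0.30 log units; within the scatter) is within the scatter, so the two numbers cannot be told apart with confidence.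

Compound 3 `CC#C[C@@H](Cc1nnn[nH]1)c1ccc(OCc2ccc3scc(C4CC4)c3c2)cc1` has not yet been measured. It differs from compound 2 in one place: cyclopropyl in place of 2-methylpyridin-3-yl on an aromatic carbon. For the measured compounds named here, no measured step involves a cyclopropyl group or this part of the shared core, so nothing bears directly on this change. Going by the values given here, the only step seen so far, from compound 1 to compound 2, was within the scatter. On this basis no step beyond the scatter is expected in this assay, in either direction, and the step from compound 2 to compound 3 is expected to be about a 1.2-fold higher number from compound 2 to compound 3 (0.08 log units; within the scatter). Compound 3 is therefore estimated at 0.22 h in this assay, with a range from 0.09 h to 0.55 h.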

Compound 3, half-life: 1.72 h
Beside the measured number, compound 3's estimate is 7.8-fold (0.89 log units) below it; the measured number lies above the stated range.
By their numbers in this assay, from the lowest: compounds 2 and 1 (each within the scatter of the next); then compound 3.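

At this position, an aromatic carbon of a five-membered aromatic ring with 1 sulfur, two ring bonds from the ring sulfur, the group can matter in this assay: replacing 2-methylpyridin-3-yl with cyclopropyl gives a 9.4-fold higher number from compound 2 to compound 3 (0.97 log units; beyond the scatter) and replacing 5-(2-methoxyethoxy)-2-methylphenyl with cyclopropyl gives a 4.7-fold higher number from compound 1 to compound 3 (0.67 log units; beyond the scatter) on the same shared core. Among the compounds shown here, the two groups carrying a six-membered aromatic ring could not be told apart, so the earlier compounds gave no sign of this sensitivity, whereas cyclopropyl, with its three-membered non-aromatic ring of carbon only, stands clear of both. No supporting data are available to explain why the compound lasts longer with this change.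

The three compounds cannot show whether this result is particular to cyclopropyl or would extend to other small carbon groups, such as an ethyl chain or a cyclobutyl ring. An unsubstituted phenyl ring, or a cyclopropyl ring carrying an amine or a carboxylic acid, would help show which features of the group at this position go with the longer half-life.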